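A few compounds are considered here, and "the series" means these few. Any claim that something is new, unique, unknown or untested is made for them only; others in the source may bear on it.

Measured compounds:
compound 1 `O=C1NCCc2nc(C#Cc3ccccc3)sc21`: 112 nM
compound 2 `CC1CC1C(=O)N1CCc2nc(C#Cc3ccccc3)sc2C1`: 9.4 nM

Both numbers come from an assay on HEK293 cells for positive allosteric modulation of metabotropic glutamate receptor 5 (Homo sapiens), read by FLIPR, with a stated time of 1 h; on this read-out higher numbers stand for an effect only at larger amounts of compound and lower numbers for an effect already at smaller amounts. Compound 2 holds the lower of the two values; compound 1 lies higher, and that gap is beyond the usual scatter. Compound 3 `O=C(CC1CCOCC1)N1CCc2nc(C#Cc3ccccc3)sc2C1` is not yet measured. It differs from compound 2 in one place: (oxan-4-yl)methyl in place of 2-methylcyclopropyl on a carbonyl carbon. Among the compounds with values here, no step between measured compounds covers a change of this kind, so the size of the effect is open. A modest rise is expected, a 2.7-fold higher number from compound 2 to compound 3 (0.42 log units; beyond the scatter), possibly no more than the scatter, because compound 2 already sits at 9.4 nM. For compound 3 the estimate is 25 nM, with a range from 6 nM to 110 nM.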

Compound 3, half-maximal effective concentration: 470 nM
Compound 3: middle estimate off by 19-fold (1.27 log units), on the low side; the measured number lies above the stated range.
By their numbers in this assay, from the lowest: compound 2; then compound 1; then compound 3.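

The group on this carbonyl carbon strongly affects the read-out: in this assay, (oxan-4-yl)methyl in place of 2-methylcyclopropyl gives a 50-fold higher number from compound 2 to compound 3 (1.70 log units; beyond the scatter) on an otherwise unchanged core. The entering group has more heavy atoms and adds a ring oxygen, so the two differences arrive together and this single step cannot separate them. No measurement on hand accounts for the step. Open, going by these compounds, is whether cyclohexylmethyl, which keeps the six-membered ring without the oxygen, would lie nearer compound 2 or compound 3.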